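A few compounds are considered here, and "the series" means these few. Any claim that something is new, unique, unknown or untested is made for them only; others in the source may bear on it.

Compound 1 `Cc1cc(C)c(S(=O)(=O)N2CCC(N3CCC(C)CC3)CC2)c(C)c1`: 0.0833 h
Compound 2 `CCc1cc(Br)ccc1S(=O)(=O)N1CCC(N2CCC(C)CC2)CC1`: 0.152 h
Compound 3 `COc1ccccc1-c1cccc(S(=O)(=O)N2CCC(N3CCC(C)CC3)CC2)c1`: 0.25 h

These values come from an ADME assay on S9 fraction from liver (Mus musculus, strain ICR/CD-1) for metabolic stability, read by LC-MS, using NADPH, with a stated time of 5 min, tested at 2 uM; a lower number here means that the compound disappears faster, a higher number that the compound lasts longer. Compound 3 and compound 2 sit within the usual scatter of each other, while compound 1 has a shorter half-life than compound 3, by more than the scatter. Compound 4 `CC1CCN(C2CCN(S(=O)(=O)c3cccc(-c4ccccc4F)c3)CC2)CC1` has not yet been measured. It carries fluoro in place of methoxy on an aromatic carbon, ortho to a large group: fluoro in place of methoxy on an aromatic carbon. Among the measured compounds shown here, no measured pair differs in one place, so the data give no direct guide to this swap, and no change beyond the scatter is expected in this assay. The expected step is a 1.2-fold higher number from compound 3 to compound 4 (0.08 log units; within the scatter). For compound 4 the estimated value is 0.3 h, with an expected range of 0.15 h to 0.6 h.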

Compound 4, half-life: 0.283 h
Beside the measured number, compound 4's estimate is 1.1-fold (0.03 log units) above it; the measured number falls inside the stated range.
By their numbers in this assay, from the lowest: compounds 1, 2, 3 and 4 (each within the scatter of the next, the first and the last beyond it).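

Among the compounds shown here, compounds 3 and 4 form the first pair that differs in only one place, 2-methoxyphenyl against 2-fluorophenyl, and in this assay the step is a 1.1-fold higher number from compound 3 to compound 4 (0.05 log units; within the scatter) for this swap. On this aromatic carbon, ortho to a large group, methoxy and fluoro therefore read alike, even though fluoro has fewer heavy atoms and no hydrogen-bond acceptor. Nothing measured here offers a reason for this. From the compounds shown here alone, whether an amine, a carboxylic acid or a longer chain on this carbon would read differently stays open. So does whether the same swap would read alike on another core.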